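The source may hold more compounds than are shown below. What is called first, only, known or untested is meant among the compounds shown, and "the series" means these compounds.

Within the data shown here, compound 1 `O=CN1N=C(c2ccc(Cl)cc2)CC1c1cn(-c2ccccc2)nc1-c1ccc(Cl)c(Cl)c1` and compound 2 `CCC(=O)N1N=C(c2ccc(F)cc2)CC1c1cn(-c2ccccc2)nc1-c1ccc(Cl)c(Cl)c1` share a core but differ in more than one place, so no single step joins them. In a functional assay on the whole organism (strain Wistar) for inhibition, with Rattus norvegicus as the target, read by paw edema, with stated times of 30 min and 120 min, at a dose of 50 mg/kg by the oral route (a higher number here means more inhibition at the dose given (going by the name of the read-out), a lower number less inhibition), compound 1 gives 57.8%. In this assay compound 2 gives 75.6%, the higher of the two numbers, with a gap to compound 1 beyond the scatter. Compound 3 `Fc1ccc(C2=NNC(c3cn(-c4ccccc4)nc3-c3ccc(Cl)c(Cl)c3)C2)cc1` is still to be measured; against compound 2 the change is hydrogen in place of propanoyl on an amine nitrogen in a ring. Among the measured compounds shown here, no measured pair shows this change, so the direction is open, though a fall beyond the scatter seems somewhat more likely, and the step expected is a number 20.6 percentage points lower from compound 2 to compound 3 (beyond the scatter). Compound 3 is estimated at 55%, within 35% to 75%.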

Compound 3, a percentage reported as inhibition, in the whole organism at one dose (the size of the read-out at that dose, not a potency): 46.1%
Compound 3: middle estimate off by 8.9 percentage points, on the high side; the measured number falls inside the stated range.
By their numbers in this assay, from the lowest: compound 3; then compound 1; then compound 2.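

Among these compounds, replacing propanoyl with hydrogen on the amine nitrogen in the ring gives a number 29.5 percentage points lower from compound 2 to compound 3 (beyond the scatter) in this assay and is the first single-place step. It shows that the number at this dose depends on what this nitrogen carries, at least with the 4-fluorophenyl group in place. Nothing measured here accounts for the fall.

Compound 1 differs from compound 2 in more than one place, so it does not separate the effect of this position. As far as these compounds go, how an acetyl or a butanoyl on this nitrogen would compare with propanoyl remains open.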